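Weak Growth Inhibitors and a Phenyl to Hydroxymethyl Swap

The compounds below may be only part of what the source reports. "The series", "measured", "known", "first", "only" and "open" are said of these compounds alone.

Measured so far:
compound 1, `C[Se]c1nc([Se]C)c2cccnc2n1`: "not determined" (no result reported)
compound 2, `CCCCCSc1nc(NCc2ccc([Se]C)cc2)c2ccccc2n1`: 50000 nM
compound 3, `CSc1nc(NCCCCc2ccccc2)c2ccccc2n1`: > 100000 nM

In a functional assay on HTB-54 cells (Homo sapiens) for cytotoxicity, read by MTT assay, with a stated time of 72 h (a lower number here means a stronger inhibitor of growth, a higher number a weaker inhibitor of growth), compound 2 gives 50000 nM. For compound 3 the value > 100000 nM is only a limit of the assay, not a number, because compound 3 sits at the limit of > 100000 nM in this assay, at which 1 of the 3 values shown sits. Nothing connects the two measured compounds by a single change, so only their two values can be compared. Compound 4, `CSc1nc(NCCCCCO)c2ccccc2n1`, is not yet measured. It differs from compound 3 by hydroxymethyl in place of phenyl on a saturated chain carbon, four bonds along the chain from a nitrogen on an aromatic ring. With compound 3 at the limit, compound 4 is expected to stay weak, and the expected step is a step that the limit leaves unreadable from compound 3 to compound 4, not beyond the scatter. For compound 4 the estimate is 120000 nM, ranging from 40000 nM to 400000 nM.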

Compound 4, concentration for total growth inhibition: 71400 nM
Beside the measured number, compound 4's estimate is 1.7-fold (0.23 log units) above it, within the range that was stated.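

Hydroxymethyl in place of phenyl on a saturated chain carbon, four bonds along the chain from a nitrogen on an aromatic ring, gives an at least 1.4-fold lower number from compound 3 to compound 4 (0.14 log units; that floor lies within the scatter). So this position can lose the phenyl ring without any sign of a higher number, and compound 4 gives a real value for this chain. The full size of the step cannot be read, because compound 3 sits at a limit, not a number: the limit of > 100000 nM in this assay, at which 1 of the 4 values shown sits.

Still open, going by these compounds, is whether an amine or a carboxylic acid in place of hydroxymethyl, or a longer chain, would move the number beyond the scatter.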